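The source may report more compounds than this note shows. Statements on the series, on what has been measured and on what is new or still open speak of the compounds shown alone.

Series notes, cyclohexanecarboxamide-bearing benzothiazoles with a second amide varied at its carbonyl carbon, read in a functional assay on WI-38 VA13 cells (Homo sapiens) for cytotoxicity; a lower number here means that less compound is needed, a higher number that more compound is needed for the effect.

Compound 1 `O=C(Nc1ccc2nc(NC(=O)C3CCCCC3)sc2c1)c1ccccc1Oc1ccccc1` gives 0.1 ug/mL in this assay. Compound 2 `O=C(Nc1ccc2nc(NC(=O)C3CCCCC3)sc2c1)c1ccc(Cl)cc1Cl` reaches only a limit of the assay in this assay, > 4 ug/mL, so no number stands for it; it sits at the limit of > 4 ug/mL in this assay, at which 1 of the 3 values shown sits. For the measured compounds named here, compound 3 `Cn1nccc1C(=O)Nc1ccc2nc(NC(=O)C3CCCCC3)sc2c1` gives 0.58 ug/mL in this assay, and the step of an at least 6.8-fold lower number from compound 2 to compound 3 (0.83 log units; beyond the scatter), with 1-methyl-1H-pyrazol-5-yl in place of 2,4-dichlorophenyl on a carbonyl carbon, is the only step between measured compounds that changes one place.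

Compound 4 `Cc1cc(C(=O)Nc2ccc3nc(NC(=O)C4CCCCC4)sc3c2)c(C)n1C` is not yet measured in this assay. It differs from compound 2 by 1,2,5-trimethyl-1H-pyrrol-3-yl in place of 2,4-dichlorophenyl on a carbonyl carbon. Going by the values given here, the change from compound 2 to compound 3 is the one measured step that bears on it: a five-membered aromatic ring with a hetero atom entering for 2,4-dichlorophenyl, and that step lowered the number beyond the scatter. A step of similar direction is expected here, an at least 4.0-fold lower number from compound 2 to compound 4 (0.60 log units; beyond the scatter), though its size is uncertain since compound 2 holds only a limit. Compound 4 is therefore expected to give about 1 ug/mL in this assay, within 0.3 ug/mL to 4 ug/mL.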

Compound 4, half-maximal effective concentration: > 6.2 ug/mL
Compound 4 was reported as a limit; the forecaster's own chance of this, stated with the estimate: 25%; at least 6.2-fold (0.79 log units) between middle value and limit.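

In this assay compound 4 stands only at a limit of the assay: the limit of > 6.2 ug/mL in this assay, at which 1 of the 4 values shown sits.

For the compounds shown here, its change against compound 3 is the first readable step between two five-membered aromatic rings at this place, on a carbonyl carbon, and it gives an at least 10-fold higher number from compound 3 to compound 4 (1.02 log units; beyond the scatter); a five-membered aromatic ring with a hetero atom therefore does not by itself bring the lower number seen for compound 3, and the outcome depends on which such ring enters. The step between compound 2 and compound 4 cannot be read, both being limits.

From the compounds shown here alone, what 1-methyl-1H-pyrrol-3-yl would give at this place stays open, and with it whether the higher number goes with the methyl groups of 1,2,5-trimethyl-1H-pyrrol-3-yl or with the ring itself. Equally open, going by these compounds, is how an amine or a carboxylic acid on the 1-methyl-1H-pyrazol-5-yl ring would read in this assay.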